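The source may hold more compounds than are shown below. What is called first, only, known or untested is meant among the compounds shown, and "the series" means these compounds.

Measured so far in a functional assay on SK-OV-3 cells (Homo sapiens) for cytotoxicity, read by MTT assay, with a stated time of 2 days; on this read-out higher numbers stand for weaker inhibition and lower numbers for stronger inhibition:

Compound 1 `CC(=O)Nc1ccc2c(c1)/C(=N\O)C(c1c[nH]c3ccc(NC(C)=O)cc13)=N2` — 21300 nM
Compound 2 `c1ccc(CO/N=C2/C(c3c[nH]c4ccccc34)=Nc3ccccc32)cc1` — 16900 nM
Compound 3 `Cc1ccc(CO/N=C2/C(c3c[nH]c4ccc(Br)cc34)=Nc3ccc(Br)cc32)cc1` — 7220 nM

Compound 2 holds the second highest of the three numbers; compound 1 sits within the usual scatter of it, while compound 3 gives a lower number that lies beyond the scatter. Within the data shown here, no pair of measured compounds differs in a single place, so no isolated step is available as a guide.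

Compound 4 `FC(F)(F)c1ccc(CO/N=C2/C(c3c[nH]c4ccccc34)=Nc3ccccc32)cc1` arises from compound 2 by trifluoromethyl in place of hydrogen on an aromatic carbon. With nothing in the series isolating this change, only a small step is expected in this assay, in either direction or none beyond the scatter. The expected step is a 1.4-fold lower number from compound 2 to compound 4 (0.15 log units; within the scatter). Compound 4 is estimated at 12000 nM, within a range from 5000 nM to 30000 nM.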

Compound 4, half-maximal inhibitory concentration: 24200 nM
Compound 4: middle estimate off by 2.0-fold (0.30 log units), on the low side, within the range that was stated.
By their numbers in this assay, from the lowest: compound 3; then compounds 2, 1 and 4 (each within the scatter of the next).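

Among these compounds, the change from phenyl to 4-(trifluoromethyl)phenyl, para to a large group, gives a 1.4-fold higher number from compound 2 to compound 4 (0.16 log units; within the scatter) in this assay as the first isolated step. This position therefore carries trifluoromethyl with no change that stands clear of the scatter. No supporting measurement accounts for this result.

Still open, from the compounds shown here alone, is whether an amine, a carboxylic acid or a longer chain at this position would also stay within the scatter. Also open, going by these compounds, is whether trifluoromethyl gives a similar step on the core of compound 3.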